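This account rests on a few compounds, and the source may have more. Where it says the series, first, only, none or still open, it means among the compounds named here.

In a functional assay on MDA-MB-231 cells (Homo sapiens) for cytotoxicity, read by MTT assay, with a stated time of 48 h (on this read-out lower numbers stand for stronger inhibition and higher numbers for weaker inhibition), compound 1 `COc1cc(C2=NOC(c3cc(OC)c(OC)c(OC)c3)C2)ccc1O` gives 3600 nM, compound 2 `COc1cc(C2=NOC(COc3ccc(-c4nnnn4-c4cc(OC)c(OC)c(OC)c4)cc3N)C2)cc(OC)c1OC` gives 3230 nM and compound 3 `COc1ccc(-c2nnnn2-c2cc(OC)c(OC)c(OC)c2)cc1N` gives 3170 nM. Compound 2 therefore lies within the scatter of both other compounds, and the three values set no order. Next in the series is compound 4 `COc1ccc(F)c(C2=NOC(COc3ccc(-c4nnnn4-c4cc(OC)c(OC)c(OC)c4)cc3N)C2)c1`, with 2-fluoro-5-methoxyphenyl in place of 3,4,5-trimethoxyphenyl on a carbon with a double bond to nitrogen. No measured step sizes this change. Compound 3 lacks the exchanged group and still gives 3170 nM, so no step beyond the scatter is expected, in either direction. The expected change in this assay is a 1.1-fold lower number from compound 2 to compound 4 (0.03 log units; within the scatter). For compound 4 the estimate is 3000 nM, with an expected range of 1000 nM to 9000 nM.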

Compound 4, half-maximal inhibitory concentration: 2830 nM
Compound 4: the middle estimate sits 1.1-fold (0.03 log units) above what was measured; low and high end bracket the measured number.
By their numbers in this assay, from the lowest: compounds 4, 3, 2 and 1 (each within the scatter of the next).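

In this assay, for the compounds shown here, 2-fluoro-5-methoxyphenyl in place of 3,4,5-trimethoxyphenyl on a carbon with a double bond to nitrogen gives a 1.1-fold lower number from compound 2 to compound 4 (0.06 log units; within the scatter) as the first measured step at this position. The entering group has fewer heavy atoms and hydrogen-bond acceptors, yet the step stays within the scatter. No measured evidence bears on this result. On these data alone, whether an amine or a carboxylic acid on the phenyl ring at this position would give a step beyond the scatter remains open.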